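The source may report more compounds than this note shows. Statements on the series, on what has been measured and on what is new or still open speak of the compounds shown alone.

Measured compounds:
compound 1, `O=c1[nH]c(=O)n([C@H]2C[C@H](O)[C@@H](CO)O2)cc1[N+](=O)[O-]`; in an ADME assay on L1210/0 cells (Mus musculus) for cytotoxicity, with a stated time of 48 h (a higher number here means a weaker inhibitor, a lower number a stronger inhibitor), compound 1 gives 130 nM.
compound 2, `C[S+]([O-])c1cn([C@H]2C[C@H](O)[C@@H](CO)O2)c(=O)[nH]c1=O`; in this assay compound 2 gives only a limit, > 200000 nM.
compound 3, `CCCC#Cc1cn([C@H]2C[C@H](O)[C@@H](CO)O2)c(=O)[nH]c1=O`; in this assay compound 3 gives only a limit, > 200000 nM.

Compound 1 is the only one of the three with a read number. Compound 2 and compound 3 both sit at the limit of > 200000 nM in this assay, at which 2 of the 3 values shown sit, so the step of an at least 1500-fold higher number from compound 1 to compound 3 (3.18 log units; beyond the scatter) and the step of an at least 1500-fold higher number from compound 1 to compound 2 (3.18 log units; beyond the scatter) are read as lower bounds, while the step that the two limits leave unreadable from compound 2 to compound 3 cannot be read at all. Compound 3 therefore stands at the limit, with no measured number of its own.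

Compound 4, `CCCCCCc1cn([C@H]2C[C@H](O)[C@@H](CO)O2)c(=O)[nH]c1=O`, differs from compound 3 by hexyl in place of pent-1-yn-1-yl on an aromatic carbon. Within the data shown here, no measured step changes one chain on that aromatic carbon for another; the only step touching compound 3, a step that the two limits leave unreadable from compound 2 to compound 3, gives no size, and the step of an at least 1500-fold higher number from compound 1 to compound 3 (3.18 log units; beyond the scatter) only says the chain sits far from compound 1. The step of a number no higher from compound 3 to compound 4 (the limit leaves the size open) is therefore expected to show no readable change, and compound 4 is expected to stay at the limit as well, estimated at 200000 nM with a range of 50000 nM to 600000 nM.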

Compound 4, half-maximal inhibitory concentration: > 200000 nM
Compound 4: a limit, no number; the forecaster's own chance of this, stated with the estimate: 80%; the middle value lies on the limit itself.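

With the triple bond gone, hexyl on this aromatic carbon still gives no read number, and the change from nitro is an at least 1500-fold higher number from compound 1 to compound 4 (3.18 log units; beyond the scatter), a lower bound only. The steps from compound 2 and compound 3 to compound 4 cannot be read, with limits on both sides. Among the groups shown at this place, only the nitro of compound 1 gives a read number in this assay, and the three others all stop at the same point: the limit of > 200000 nM in this assay, at which 3 of the 4 values shown sit.

Still open, as far as these compounds go, is whether a short chain such as ethyl, or an amine, on this carbon would return a read number. How far compound 2, compound 3 and compound 4 lie beyond the limit, and whether they differ among themselves, also remains undetermined.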